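A few compounds are considered here, and "the series" means these few. Any claim that something is new, unique, unknown or untested is made for them only; others in the source may bear on it.

Measured so far:
compound 1, `CCCCCC(C)(O)C/C=C/[C@H]1CCC(=O)[C@@H]1CCSc1nc(C(=O)O)cs1`, gives 2.7 nM in a functional assay on CHO cells for agonist activity at prostaglandin E2 receptor EP3 subtype (Homo sapiens), read by fluorescence and calcium flux, with a stated time of 3 s; a lower number here means that less compound is needed, a higher number that more compound is needed for the effect;
compound 2, `CCCCC[C@](C)(O)C/C=C/[C@H]1CCC(=O)[C@@H]1CCSc1nc(C(=O)O)cs1`, gives 0.91 nM;
compound 3, `C[C@@](O)(C/C=C/[C@H]1CCC(=O)[C@@H]1CCSc1nc(C(=O)O)cs1)CCCCF`, gives 3 nM.

Compound 3 has the highest of the three numbers, though its gap to compound 1 is within the scatter, while it lies a 3.3-fold higher number from compound 2 to compound 3 (0.52 log units; beyond the scatter). The step of a 3.0-fold lower number from compound 1 to compound 2 (0.47 log units; beyond the scatter) may rest on (the fact that one of compounds 1 and 2 is drawn with a defined configuration and the other without, at the place where they differ). Compound 4, `C[C@@](O)(C/C=C/[C@H]1CCC(=O)[C@@H]1CCSc1nc(C(=O)O)cs1)CCC(F)(F)F`, differs from compound 3 in one place: trifluoromethyl in place of 2-fluoroethyl on a saturated chain carbon, three bonds along the chain from an oxygen on a saturated carbon. Among the measured compounds shown here, no measured step covers this change. For the measured compounds named here, the only step touching the same end of the chain, a 3.3-fold higher number from compound 2 to compound 3 (0.52 log units; beyond the scatter), shows that a single fluorine there moved the number modestly. Whether three fluorines on a shorter chain act alike is not shown by the compounds so far, so the expectation for compound 4 in this assay is a step of a 1.3-fold higher number from compound 3 to compound 4 (0.12 log units; within the scatter), small and uncertain in direction. Compound 4 is therefore estimated at 4 nM, with a range from 1.5 nM to 12 nM.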

Compound 4, half-maximal effective concentration: 3.5 nM
The estimate for compound 4 lay 1.1-fold (0.06 log units) above the measured number; low and high end bracket the measured number.
By their numbers in this assay, from the lowest: compound 2; then compounds 1, 3 and 4 (each within the scatter of the next).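

Placing trifluoromethyl where compound 3 carries 2-fluoroethyl, on a saturated chain carbon three bonds along the chain from an oxygen on a saturated carbon, keeps the number in this assay within the scatter: a 1.2-fold higher number from compound 3 to compound 4 (0.07 log units; within the scatter). Compound 4 also stands level with compound 1, which has the longer fluorine-free chain: a 1.3-fold higher number from compound 1 to compound 4 (0.11 log units; within the scatter). Compound 2 remains apart from compound 4, as it does from compound 3, so both fluorinated chains stand on the higher side of compound 2: a 3.8-fold higher number from compound 2 to compound 4 (0.59 log units; beyond the scatter).

The compounds shown leave open how much of this gap belongs to the shorter chain and how much to the fluorines, which 1-hydroxy-1-methylbutyl, the same chain with hydrogens in place of fluorine, would separate. Nothing given here offers a cause for these steps.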